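Replacing 4,5-dimethylfuran-2-yl with 1H-pyrrol-2-yl: compound 3 to compound 4

The source may report more compounds than this note shows. Statements on the series, on what has been measured and on what is new or still open speak of the compounds shown alone.

Measured so far in a functional assay on HCT-116 cells (Homo sapiens) for antiproliferative activity, read by resazurin assay, with a stated time of 5 days; a lower number here means a stronger inhibitor, a higher number a weaker inhibitor:
- Compound 1 `COCc1ccc(C(=O)NCc2ccc3cc(C(=O)NO)sc3c2F)o1` gives 310 nM
- Compound 2 `Cc1ncoc1C(=O)NCc1ccc2cc(C(=O)NO)sc2c1F` gives 210 nM
- Compound 3 `Cc1cc(C(=O)NCc2ccc3cc(C(=O)NO)sc3c2F)oc1C` gives 470 nM

Compound 3 sits at the upper end of these numbers, level within the scatter with compound 1 (a 1.5-fold higher number from compound 1 to compound 3 (0.18 log units; within the scatter)) and modestly apart from compound 2 (a 2.2-fold higher number from compound 2 to compound 3 (0.35 log units; beyond the scatter)). Compound 4 `O=C(NCc1ccc2cc(C(=O)NO)sc2c1F)c1ccc[nH]1` has 1H-pyrrol-2-yl in place of 4,5-dimethylfuran-2-yl on a carbonyl carbon. Going by the values given here, no measured compound carries this group. The closest guides are the other exchanges at this carbonyl carbon, which are all small, such as a 1.5-fold lower number from compound 1 to compound 2 (0.17 log units; within the scatter) and the two steps above. The estimated step is therefore a 1.6-fold lower number from compound 3 to compound 4 (0.19 log units; within the scatter) in this assay and is not expected to go beyond the scatter. For compound 4 the expected value is 300 nM in a range from 130 nM to 700 nM on this estimate.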

Compound 4, half-maximal inhibitory concentration: 300 nM
Estimate against measurement, compound 4: no gap at the digits printed, within the range that was stated.
By their numbers in this assay, from the lowest: compounds 2, 4, 1 and 3 (each within the scatter of the next, the first and the last beyond it).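

In this assay, 1H-pyrrol-2-yl brings a hydrogen-bond donor and fewer heavy atoms than 4,5-dimethylfuran-2-yl, yet the number barely shifts: a 1.6-fold lower number from compound 3 to compound 4 (0.19 log units; within the scatter) and a 1.4-fold higher number from compound 2 to compound 4 (0.15 log units; within the scatter) and a 1.0-fold lower number from compound 1 to compound 4 (0.01 log units; within the scatter). A ring with no substituent and with this donor therefore fits at this carbonyl carbon as well as the three substituted rings do. Nothing available here explains this flat response. Still open, from the compounds shown here alone, is whether an amine, a carboxylic acid or a longer chain on this ring would move the number beyond the scatter.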